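From 3-bromobenzyl to 4-methylphenyl: what to expect

This account rests on a few compounds, and the source may have more. Where it says the series, first, only, none or still open, it means among the compounds named here.

Compound 1 `CCCn1c(=O)[nH]c2nc(-c3ccc(S(=O)(=O)N4CCN(c5ccc(F)cc5)CC4)cc3)[nH]c2c1=O`, compound 2 `CCCn1c(=O)[nH]c2nc(-c3ccc(S(=O)(=O)N4CCN(c5ccc(Cl)cc5F)CC4)cc3)[nH]c2c1=O` and compound 3 `CCCn1c(=O)[nH]c2nc(-c3ccc(S(=O)(=O)N4CCN(Cc5cccc(Br)c5)CC4)cc3)[nH]c2c1=O` share one core and differ only in the group carried on an amine nitrogen in a ring. In an assay on CHO cells for displacement of a labelled ligand from adenosine receptor A3 (Homo sapiens), read by scintillation counting, with a stated time of 45 min, in the presence of a further agent that is not named here (a lower number here means a stronger inhibitor, a higher number a weaker inhibitor), compound 1 gives only a limit, > 1000 nM. In this assay compound 2 likewise gives a limit, > 1000 nM. Compound 3 also reaches no more than a limit, > 1000 nM. Compound 3 therefore stands exactly where all values shown stand, at the limit of > 1000 nM in this assay, at which 3 of the 3 values shown sit. The steps a step that the two limits leave unreadable from compound 1 to compound 2, a step that the two limits leave unreadable from compound 1 to compound 3 and a step that the two limits leave unreadable from compound 2 to compound 3 accordingly cannot be read in size. Compound 4 `CCCn1c(=O)[nH]c2nc(-c3ccc(S(=O)(=O)N4CCN(c5ccc(C)cc5)CC4)cc3)[nH]c2c1=O` carries the change (4-methylphenyl in place of 3-bromobenzyl on an amine nitrogen in a ring). All three measured steps bear on it, since each of them also exchanges the group on that ring nitrogen, yet none of them shows a readable size, so nothing in these numbers gives ground to expect compound 4 to move beyond the limit. The step estimated here, a step that the limit leaves unreadable from compound 3 to compound 4, is expected to have no readable size. Compound 4 is expected to give about 2000 nM, within a range from 800 nM to 10000 nM, and most probably only a limit once more.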

Compound 4, inhibition constant: > 1000 nM
Compound 4 gave a limit, no number (the forecaster's own chance of this, stated with the estimate: 85%); the middle value is on the limit's open side.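

Compound 4 gives only a limit in this assay, as do compound 1, compound 2 and compound 3, so no new step can be read among them: the limit of > 1000 nM in this assay, at which 4 of the 4 values shown sit.

The compounds shown leave open whether these four groups on the ring nitrogen differ at all in this assay.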